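The compounds below may be only part of what the source reports. "The series", "measured", "known", "first", "only" and "open" are said of these compounds alone.

Compound 1 `Cc1ccc(S(=O)(=O)N2C=CNC(=O)[C@H]2CC(=O)N[C@@H]2CCCc3ccccc32)cc1`: in an in vitro functional assay on cells for antagonist activity at B1 bradykinin receptor (Homo sapiens), read by luminescence and calcium flux, with a stated time of 2 h (on this read-out higher numbers stand for weaker inhibition and lower numbers for stronger inhibition), compound 1 gives 3.3 nM.
Compound 2 `Cc1ccc(S(=O)(=O)N2C=CNC(=O)[C@H]2CC(=O)NC2CCOCC2(C)C)cc1`: in this assay compound 2 gives 25.2 nM.

Among these two numbers compound 2 stands highest; its only neighbour is compound 1, reached by a 7.6-fold higher number from compound 1 to compound 2 (0.88 log units; beyond the scatter). Compound 3 `CCN1CC[C@H](NC(=O)C[C@@H]2C(=O)NC=CN2S(=O)(=O)c2ccc(C)cc2)C(C)(C)C1` is not yet measured. It differs from compound 2 by a group of 10 heavy atoms (9 carbon, 1 nitrogen; one six-membered non-aromatic ring with 1 hetero atom) in place of a group of 8 heavy atoms (7 carbon, 1 oxygen; one six-membered non-aromatic ring with 1 hetero atom), on an amide-type nitrogen. For the measured compounds named here, the single measured step, a 7.6-fold higher number from compound 1 to compound 2 (0.88 log units; beyond the scatter), concerns a different exchange at that nitrogen and so offers only loose guidance. Compound 3 is expected to give about 15 nM, in a range from 4 nM to 60 nM. That corresponds to an estimated 1.7-fold lower number from compound 2 to compound 3 (0.23 log units; within the scatter), a change expected to sit close to the scatter.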

Compound 3, half-maximal inhibitory concentration: 0.63 nM
Beside the measured number, compound 3's estimate is 24-fold (1.38 log units) above it; the measured number lies below the stated range.
By their numbers in this assay, from the lowest: compound 3; then compound 1; then compound 2.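

In this assay, swapping the oxygen-containing six-membered non-aromatic ring at this amide-type nitrogen for the nitrogen-containing one gives a 40-fold lower number from compound 2 to compound 3 (1.60 log units; beyond the scatter), so a change of hetero atom and ring substituents can matter greatly here. The same group also gives a 5.2-fold lower number from compound 1 to compound 3 (0.72 log units; beyond the scatter), so an aromatic ring in this group is not needed for a low number. No measurement shown explains these gains.

On these data alone, it remains open whether the ring nitrogen or the group it carries accounts for the change. A methyl group or a plain hydrogen on that ring nitrogen would help separate the two.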